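The compounds below may be only part of what the source reports. "The series", "measured", "known", "first", "only" and "open" are said of these compounds alone.

Measured so far:
compound 1 `CC1(COc2ccc(-c3ccc(F)cc3)cc2)Cn2cc([N+](=O)[O-])nc2O1`: > 64000 nM
compound 2 `O=[N+]([O-])c1cn2c(n1)OC(COCc1ccc(OC(F)(F)F)cc1)C2`: > 64000 nM

Both compounds were tested in an ADME assay on MRC5 cells (Homo sapiens) for cytotoxicity, read by fluorescence, with a stated time of 72 h; a lower number here means a stronger inhibitor, a higher number a weaker inhibitor. Compound 1 gives > 64000 nM, which is a limit of the assay and not a number. Compound 2 gives > 64000 nM, which is also a limit. The series therefore stands as follows: the limit of > 64000 nM in this assay, at which 2 of the 2 values shown sit. For the measured compounds named here, compound 1 has no numeric value from which to count a step, and no step between measured compounds is available.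

The next compound is compound 3 `CC1(COc2ccc(F)cc2)Cn2cc([N+](=O)[O-])nc2O1`, which keeps the core of compound 1 and carries fluoro in place of 4-fluorophenyl on an aromatic carbon. The expectation rests on compound 1, whose reading is the limit > 64000 nM. No change beyond the usual scatter is expected in this assay, and no direction can be called. The expected step of a number no higher from compound 1 to compound 3 (the limit leaves the size open) is an estimate anchored on a limit, and compound 3 may well return only a limit too. For compound 3 the estimated value is 64000 nM, with an expected range of 25000 nM to 64000 nM.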

Compound 3, half-maximal inhibitory concentration: > 64000 nM
Compound 3: a limit, no number (the forecaster's own chance of this, stated with the estimate: 80%); the middle value sits exactly at the limit.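

Compound 1 and compound 3 both return only a limit in this assay, and no step can be read between them. The compounds shown leave open what number any of them would give, and whether fluoro in place of 4-fluorophenyl shifts the reading at all.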